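This account rests on a few compounds, and the source may have more. Where it says the series, first, only, none or still open, it means among the compounds named here.

Of the compounds shown here, three sharing one core have been measured in an ADME assay (liver) for metabolic stability, with Liver microsome (Rattus norvegicus) as the target, using microsomes and NADPH, with a stated time of 30 min, tested at 1 uM; a higher number here means faster removal of the compound, a lower number slower removal. Compound 1 `Nc1ccc(S(=O)(=O)N2CCN(c3ncc(C(O)(C(F)(F)F)C(F)(F)F)cc3C#CCCO)CC2)cn1` gives 68 mL.min-1.g-1. Compound 2 `CC(C)(C)n1cc(-c2cc(C(O)(C(F)(F)F)C(F)(F)F)cnc2N2CCN(S(=O)(=O)c3ccc(N)nc3)CC2)cn1` gives 459 mL.min-1.g-1, and compound 3 `Nc1ccc(S(=O)(=O)N2CCN(c3ncc(C(O)(C(F)(F)F)C(F)(F)F)cc3-c3ccccc3O)CC2)cn1` gives 125 mL.min-1.g-1. Among these three numbers compound 3 stands second highest; compound 1 is nearest to it, and the pair differ within the usual scatter, whereas compound 2 stands furthest from it, with a 3.7-fold lower number from compound 2 to compound 3 (0.56 log units; beyond the scatter) marking a step beyond the scatter.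

Compound 4 `Nc1ccc(S(=O)(=O)N2CCN(c3ncc(C(O)(C(F)(F)F)C(F)(F)F)cc3-c3cccc4[nH]ncc34)CC2)cn1` differs from compound 3 in one place: 1H-indazol-4-yl in place of 2-hydroxyphenyl on an aromatic carbon. Among the compounds with values here, no measured step replaces one aryl group on that carbon with a bicyclic one, so the bearing steps are indirect. The step of a 3.7-fold lower number from compound 2 to compound 3 (0.56 log units; beyond the scatter) shows that exchanging the group on that aromatic carbon can move the number modestly in this assay, and a 1.8-fold higher number from compound 1 to compound 3 (0.26 log units; within the scatter) shows that it can also leave the number within the scatter. The account therefore expects at most a modest step, more likely upward than downward, and cannot rule out none beyond the scatter. For compound 4 the expected value in this assay is 180 mL.min-1.g-1, with a range from 80 mL.min-1.g-1 to 400 mL.min-1.g-1, which is estimated to mean a step of a 1.4-fold higher number from compound 3 to compound 4 (0.16 log units; within the scatter).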

Compound 4, intrinsic clearance in microsomes: 93 mL.min-1.g-1
For compound 4 the middle estimate is 1.9-fold (0.29 log units) above the measured one; measured number inside the range.
By their numbers in this assay, from the lowest: compounds 1, 4 and 3 (each within the scatter of the next); then compound 2.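

In this assay, 1H-indazol-4-yl, a group with two aromatic rings, is accommodated on this aromatic carbon with no step beyond the scatter from the two smaller-looking comparators: a 1.3-fold lower number from compound 3 to compound 4 (0.13 log units; within the scatter) and a 1.4-fold higher number from compound 1 to compound 4 (0.14 log units; within the scatter). Going from 7 heavy atoms in 2-hydroxyphenyl to 9 in 1H-indazol-4-yl therefore leaves the number where it was, and a five-membered aromatic ring at this position does not by itself go with the high number of compound 2, as a 4.9-fold lower number from compound 2 to compound 4 (0.69 log units; beyond the scatter) shows. Compounds 1, 3 and 4 now form one group within the scatter, with compound 2 and its 1-(tert-butyl)-1H-pyrazol-4-yl alone apart from them, and nothing available here bears on why this is so.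

The compounds shown do not separate the tert-butyl group from the pyrazole ring in compound 2, so it stays open whether a 1-methyl-1H-pyrazol-4-yl group on this carbon would stand with compound 2 or with compound 4. Going by these compounds, it also stays open whether an unsubstituted phenyl group, or a phenyl ring carrying an amine or a carboxylic acid, would stay within this group.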